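Lengthening the ether side group of compound 3

The source may report more compounds than this note shows. Statements on the series, on what has been measured and on what is new or still open speak of the compounds shown alone.

Measured in a functional assay on RS4-11 cells (Homo sapiens) for inhibition, read by CCK-8 assay, with a stated time of 72 h; on this read-out lower numbers stand for stronger inhibition and higher numbers for weaker inhibition:
- compound 1 `CC1(C)CCC(CN2CCN(c3ccc(C(=O)NS(=O)(=O)c4ccc(NCC5CCOCC5)c([N+](=O)[O-])c4)c(Oc4cnc5[nH]ccc5c4)c3)CC2)=C(c2ccc(C(F)(F)F)cc2)C1`: 6.2 nM
- compound 2 `CC1(C)CCC(CN2CCN(c3ccc(C(=O)NS(=O)(=O)c4ccc(NCC5CCOC5)c([N+](=O)[O-])c4)c(Oc4cnc5[nH]ccc5c4)c3)CC2)=C(c2ccc(C(F)(F)F)cc2)C1`: 24.2 nM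
- compound 3 `CC1(C)CCC(CN2CCN(c3ccc(C(=O)NS(=O)(=O)c4ccc(OC5CCOCC5)c([N+](=O)[O-])c4)c(Oc4cnc5[nH]ccc5c4)c3)CC2)=C(c2ccc(C(F)(F)F)cc2)C1`: 375 nM

Compound 3 has the highest number of the three, so it is the weakest inhibitor here. This shows in a 15-fold higher number from compound 2 to compound 3 (1.19 log units; beyond the scatter) and in a 60-fold higher number from compound 1 to compound 3 (1.78 log units; beyond the scatter). Both large steps replace an amino-linked side group with (oxan-4-yl)oxy.

Compound 4 `CC(Oc1ccc(S(=O)(=O)NC(=O)c2ccc(N3CCN(CC4=C(c5ccc(C(F)(F)F)cc5)CC(C)(C)CC4)CC3)cc2Oc2cnc3[nH]ccc3c2)cc1[N+](=O)[O-])C1CCOCC1` differs from compound 3 at one place: 1-(oxan-4-yl)ethyl in place of oxan-4-yl on an oxygen on an aromatic ring. Here 1-(oxan-4-yl)ethyl takes the place of oxan-4-yl on an oxygen on an aromatic ring.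

For the measured compounds named here, no measured step makes this exact change. The nearest guide is the modest 3.9-fold higher number from compound 1 to compound 2 (0.59 log units; beyond the scatter), which alters only the ring of that side group. The new group also resembles the (oxan-4-yl)methyl part of compound 1 at 6.2 nM, so a modest move towards a lower number seems likely, though the data cannot rule out no real change. The expected step in this assay is a 2.5-fold lower number from compound 3 to compound 4 (0.40 log units; beyond the scatter). Compound 4 is estimated at 150 nM, with an expected range of 30 nM to 600 nM.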

Compound 4, half-maximal inhibitory concentration: 269 nM
For compound 4 the middle estimate is 1.8-fold (0.25 log units) below the measured one, within the range that was stated.
By their numbers in this assay, from the lowest: compound 1; then compound 2; then compounds 4 and 3 (each within the scatter of the next).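

In this assay, putting 1-(oxan-4-yl)ethyl in place of oxan-4-yl on the oxygen gives a 1.4-fold lower number from compound 3 to compound 4 (0.14 log units; within the scatter), so this longer ether side group cannot be told apart from the shorter one. It also does not close the gap to the amino-linked compounds, with an 11-fold higher number from compound 2 to compound 4 (1.05 log units; beyond the scatter) and a 43-fold higher number from compound 1 to compound 4 (1.64 log units; beyond the scatter) as the large steps that remain, and among these four compounds both oxygen-linked side groups stand apart from both amino-linked ones. No measured evidence here explains that gap. Still open, as far as these compounds go, is whether the oxygen link or the side group beyond it matters more. (Oxan-4-yl)methoxy and (1-(oxan-4-yl)ethyl)amino on the same aromatic carbon would help to separate the two, as would a longer chain on the oxygen.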